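A few compounds are considered here, and "the series" means these few. Any claim that something is new, unique, unknown or untested is made for them only; others in the source may bear on it.

Measured compounds in a functional assay on NCI-H460 cells (Homo sapiens) for cytotoxicity, read by MTT assay; on this read-out lower numbers stand for stronger inhibition and higher numbers for weaker inhibition:

Compound 1, `COc1cc(/C=C/C(=O)c2sc(Nc3ccc(Cl)cc3)nc2C)cc(OC)c1OC`, gives 22000 nM.
Compound 3, `Cc1nc(Nc2ccc(Cl)c(Cl)c2)sc1C(=O)/C=C/c1ccccc1`, gives 22700 nM.
Compound 2, `Cc1cccc(Nc2nc(C)c(C(=O)/C=C/c3ccccc3Cl)s2)c1`, gives only a limit of the assay, > 25000 nM, and not a number.

The values of compound 1 and compound 3 lie within the usual scatter of one another, so no order can be read between them. Going by these compounds, compound 2 stands apart only in that its result is a limit, as stated in the limit of > 25000 nM in this assay, at which 1 of the 3 values shown sits, so its true number is unknown. All three compounds share the same core and are weak in this assay.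

Compound 4, `Cc1cccc(Nc2nc(C)c(C(=O)/C=C/c3ccc(Cl)cc3)s2)c1`, differs from compound 2 in one place: 4-chlorophenyl in place of 2-chlorophenyl on a double-bonded chain carbon bound to a double-bonded chain carbon. Going by the values given here, no pair among the measured compounds differs only in this way, so the effect of this change has not been seen directly. With all three measured compounds weak, there is no ground to expect compound 4 to move beyond the scatter in either direction. Compound 4 is therefore estimated at 20000 nM in this assay, with a range from 7000 nM to 60000 nM. The step this estimate implies, an at least 1.2-fold lower number from compound 2 to compound 4 (0.09 log units; that floor lies within the scatter), is expected to be small.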

Compound 4, half-maximal inhibitory concentration: > 25000 nM
Compound 4: no number, only a limit (the forecaster's own chance of this, stated with the estimate: 40%); at least 1.2-fold (0.09 log units) between middle value and limit.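

Compound 2 and compound 4 each give only a limit of the assay and not a number, so no step can be read between them: the limit of > 25000 nM in this assay, at which 2 of the 4 values shown sit.

The compounds shown leave open whether 4-chlorophenyl in place of 2-chlorophenyl shifts the true number in this assay at all, and in which direction.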